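Furan-3-yl for 1H-pyrrol-1-yl on compound 1

The compounds below may be only part of what the source reports. "The series", "measured", "known", "first", "only" and "open" are said of these compounds alone.

In a functional assay on HCT-116 cells (Homo sapiens) for antiproliferative activity, read by sulforhodamine B assay (a lower number here means a stronger inhibitor, a higher number a weaker inhibitor), compound 1 `CN1CCN(c2ccc(N/C=C3\C(=O)NC(=O)c4ccc(-n5cccc5)cc43)cc2)CC1` gives 1500 nM. Compound 2 `O=C1NC(=O)c2ccc(I)cc2/C1=C/Nc1ccc(CN2CCCCC2)cc1` gives 2700 nM, and compound 3 `O=C1NC(=O)c2ccc(-n3cccc3)cc2/C1=C/Nc1ccc(CN2CCCCC2)cc1` gives 2700 nM. Compound 1 therefore stands level with the other two, as all three values lie within the scatter of one another.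

The next step leads to compound 4 `CN1CCN(c2ccc(N/C=C3\C(=O)NC(=O)c4ccc(-c5ccoc5)cc43)cc2)CC1`, with furan-3-yl in place of 1H-pyrrol-1-yl on an aromatic carbon. Within the data shown here, no measured compound carries furan-3-yl, so its effect has no direct precedent in this set.

Among the measured compounds shown here, two measured steps bear on the change. The closer one acts at the same place on the core, with 1H-pyrrol-1-yl in place of iodo, and gives no change at the digits printed from compound 2 to compound 3 (within the scatter). The other acts elsewhere, with (piperidin-1-yl)methyl in place of 4-methylpiperazin-1-yl, and gives a 1.8-fold higher number from compound 1 to compound 3 (0.26 log units; within the scatter). Neither step leaves the scatter, so no step beyond the scatter is expected in this assay, and no direction is favoured. For the measured compounds named here, with only three values behind it, the expectation carries a wide range.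

The expected step is no change at the digits printed from compound 1 to compound 4 (within the scatter).

Compound 4 is estimated at 1500 nM, with an expected range of 600 nM to 3800 nM.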

Compound 4, half-maximal inhibitory concentration: 1200 nM
For compound 4 the middle estimate is 1.3-fold (0.10 log units) above the measured one; low and high end bracket the measured number.
By their numbers in this assay, from the lowest: compounds 4, 1, 2 and 3 (each within the scatter of the next, the first and the last beyond it).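

In this assay, furan-3-yl on this aromatic carbon reads as a 1.3-fold lower number from compound 1 to compound 4 (0.10 log units; within the scatter), so a second five-membered aromatic ring can replace 1H-pyrrol-1-yl without a step beyond the scatter. The two groups have the same heavy-atom count and the same counted donors and acceptors, with oxygen replacing nitrogen as the ring hetero atom, and this exchange adds a second reading at this position: no change at the digits printed from compound 2 to compound 3 (within the scatter) was seen with (piperidin-1-yl)methyl elsewhere on the molecule, whereas the new step has 4-methylpiperazin-1-yl there. No supporting measurement is available to explain why these substituents read alike.

Only iodo, 1H-pyrrol-1-yl and furan-3-yl are shown at this position, so it remains open whether a primary amine, a carboxylic acid or a longer alkyl chain there would produce a step beyond the scatter. The furan-3-yl group is also shown only with 4-methylpiperazin-1-yl, which leaves its reading alongside (piperidin-1-yl)methyl open.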